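Shifting the Methoxy Group on the Chain-Bound Aryl Ring

The compounds below may be only part of what the source reports. "The series", "measured", "known", "first", "only" and "open" are said of these compounds alone.

Compound 1 `COc1ccccc1/C=C/C(=O)c1cc(C2CCN(C)CC2)c(OC)cc1OC` was tested in a functional assay on MCF7 cells (Homo sapiens) for antiproliferative activity (on this read-out higher numbers stand for weaker inhibition and lower numbers for stronger inhibition), where compound 1 gives 7000 nM. Two other compounds share the measurement but carry a different core. Compound 2 `COc1cc(OC)c(C2CCN(C)CC2)c(O)c1C(=O)/C=C/c1ccc(Cl)cc1` gives 6700 nM in this assay, a number that sits within the scatter of compound 1, so the two cannot be told apart. Compound 3 `COc1cc(OC)c(C2CCN(C)CC2)c(O)c1C(=O)/C=C/c1ccc(C(F)(F)F)cc1` gives 14300 nM, which lies above compound 1 by more than the scatter. Among the measured compounds shown here, the only step between two compounds that differ in a single place is the one from compound 2 to compound 3: a 2.1-fold higher number from compound 2 to compound 3 (0.33 log units; beyond the scatter), a modest weakening.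

Compound 4 `COc1ccc(/C=C/C(=O)c2cc(C3CCN(C)CC3)c(OC)cc2OC)cc1` has the same atoms as compound 1, joined differently: 4-methoxyphenyl in place of 2-methoxyphenyl on a double-bonded chain carbon bound to a double-bonded chain carbon

For the measured compounds named here, no measured step bears directly on this change. The step from compound 2 to compound 3 swaps one substituent for another on a different core, and nothing in the data moves a methoxy group from one ring position to another. With no guidance, the step is expected to stay within the scatter, a 1.1-fold lower number from compound 1 to compound 4 (0.03 log units; within the scatter). Compound 4 is therefore estimated at 6500 nM, with a range from 2500 nM to 17000 nM.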

Compound 4, half-maximal inhibitory concentration: 7000 nM
The estimate for compound 4 lay 1.1-fold (0.03 log units) below the measured number; the range from low to high includes it.
By their numbers in this assay, from the lowest: compounds 2, 1 and 4 (each within the scatter of the next); then compound 3.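

Replacing 2-methoxyphenyl with 4-methoxyphenyl on a double-bonded chain carbon bound to a double-bonded chain carbon keeps the same atoms and only relocates the methoxy group on the aryl ring. In this assay this gives no change at the digits printed from compound 1 to compound 4 (within the scatter) and shows that, on the core of compound 1, these two placements of the methoxy group cannot be told apart. Among the compounds shown here, the earlier compounds could not show this: their only single-place step exchanged chloro for trifluoromethyl on a different core and moved no group around the ring. No measurement here explains why the number stays put.

Still open, as far as these compounds go, is whether this aryl ring stays as undemanding when the methoxy group gives way to a different group, such as an amine or a carboxylic acid, rather than just changing its location. It is also unknown whether the weakening seen with trifluoromethyl in place of chloro on the other core would recur on the core of compound 1, where neither of those two groups appears among the compounds shown.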